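Swapping the Outer Arm: From Compound 3 to Compound 4

The compounds below may be only part of what the source reports. "The series", "measured", "known", "first", "only" and "open" are said of these compounds alone.

Of the compounds shown here, three sharing one core have been tested in a functional assay on SGC-7901 cells (Homo sapiens) for cytotoxicity, read by MTT assay, with a stated time of 48 h; on this read-out higher numbers stand for weaker inhibition and lower numbers for stronger inhibition. Compound 1 `CCN(CC)c1ccc2cc(C(=O)c3ccc(N4CCN(C(=O)CN5CCNCC5)CC4)cc3)oc2c1` carries a hydrogen on the amine nitrogen in the outermost ring and gives 1220 nM. Compound 2 `CCN(CC)c1ccc2cc(C(=O)c3ccc(N4CCN(C(=O)CN5CCN(Cc6ccc(/C=C/C(=O)OC)cc6)CC5)CC4)cc3)oc2c1` gives 740 nM. Compound 3 `CCN(CC)c1ccc2cc(C(=O)c3ccc(N4CCN(C(=O)CN5CCN(Cc6ccc(C#N)cc6)CC5)CC4)cc3)oc2c1`, in which that amine nitrogen carries a 4-cyanobenzyl group, gives 26300 nM and is the weakest of the three, as shown by a 22-fold higher number from compound 1 to compound 3 (1.33 log units; beyond the scatter) and a 36-fold higher number from compound 2 to compound 3 (1.55 log units; beyond the scatter). Compound 4 `CCOC(=O)CN1CCN(CC(=O)N2CCN(c3ccc(C(=O)c4cc5ccc(N(CC)CC)cc5o4)cc3)CC2)CC1` has not been measured; it differs from compound 3 by ethoxycarbonyl in place of 4-cyanophenyl on a saturated chain carbon bound to an amine nitrogen in a ring. Both measured steps bear on this change: attaching the 4-cyanobenzyl arm to compound 1 raised the number sharply, and the arm carrying the cyano group fared far worse than the arm of compound 2. Taking the 4-cyanophenyl part away should therefore bring the number back toward the small-substituent case of compound 1. Compound 4 is expected to show a large recovery, an 18-fold lower number from compound 3 to compound 4 (1.24 log units; beyond the scatter). The estimate for compound 4 in this assay is 1500 nM, within a range from 400 nM to 6000 nM.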

Compound 4, half-maximal inhibitory concentration: > 40000 nM
Compound 4: a limit, no number; the forecaster's own chance of this, stated with the estimate: 3%; at least 26-fold (1.42 log units) between middle value and limit.
By their numbers in this assay, from the lowest: compounds 2 and 1 (each within the scatter of the next); then compound 3. At a limit, above all of these: compound 4.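

In this assay compound 4 stands at a limit of the assay, not at a number: the limit of > 40000 nM in this assay, at which 1 of the 4 values shown sits.

Shortening the arm on this nitrogen brought no recovery, as an at least 1.5-fold higher number from compound 3 to compound 4 (0.18 log units; that floor lies within the scatter) shows, so a small arm in place of 4-cyanobenzyl does not return the number to that of compound 1, as an at least 32-fold higher number from compound 1 to compound 4 (1.51 log units; beyond the scatter) makes plain. An ester in the arm does not settle the outcome either, since compound 2 also carries one and still lies far from the ethoxycarbonyl arm, with an at least 54-fold higher number from compound 2 to compound 4 (1.73 log units; beyond the scatter).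

On these data alone, how far compound 4 lies beyond its limit stays unknown, and so does the true size of its step from compound 3. As far as these compounds go, it also remains open whether a plain ethyl group, a carboxylic acid or an unsubstituted benzyl group on this nitrogen would keep the number near that of compound 1.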